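Switching the Double Bond from Z to E: Cytotoxicity Outlook

A few compounds are considered here, and "the series" means these few. Any claim that something is new, unique, unknown or untested is made for them only; others in the source may bear on it.

Compound 1, `CCCCCCCCC#Cc1cn(C/C=C/CN2C(=O)c3ccccc3C2=O)c(=O)[nH]c1=O`: 53000 nM
Compound 2, `O=C1c2ccccc2C(=O)N1C/C=C\Cn1cc(C#CCCc2ccccc2)c(=O)[nH]c1=O`: > 100000 nM

In an ADME assay on WI-38 cells (Homo sapiens) for cytotoxicity, read by MTT assay, with a stated time of 3 days (on this read-out lower numbers stand for stronger inhibition and higher numbers for weaker inhibition), compound 1 gives 53000 nM. For compound 2 the read-out is only a limit of the assay, > 100000 nM; this is the limit of > 100000 nM in this assay, at which 1 of the 2 values shown sits. Compound 3, `O=C1c2ccccc2C(=O)N1C/C=C/Cn1cc(C#CCCc2ccccc2)c(=O)[nH]c1=O`, differs from compound 2 in a single respect: the two compounds have the same atoms and bonds and differ only in configuration as drawn: 1 of 1 stereo elements differ; a double bond is drawn Z in compound 2 and E in compound 3. Among the measured compounds shown here, no measured pair separated by this change alone exists, so the size of the step in this assay cannot be read from the numbers; with compound 2 sitting at a limit, compound 3 is expected to stay close to that limit. Compound 3 is estimated at 90000 nM, with a range from 35000 nM to 250000 nM. The expected step of an at least 1.1-fold lower number from compound 2 to compound 3 (0.04 log units; that floor lies within the scatter) lies within the scatter.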

Compound 3, half-maximal inhibitory concentration: 31000 nM
The estimate for compound 3 lay 2.9-fold (0.46 log units) above the measured number; measured number below the stated range.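

In this assay, the configuration of the double bond alone now gives a readable difference: an at least 3.2-fold lower number from compound 2 to compound 3 (0.50 log units; beyond the scatter). Compound 2 stands at a limit, so this step has a floor and no exact size: the limit of > 100000 nM in this assay, at which 1 of the 3 values shown sits. With the E double bond in both compounds, phenyl in place of hexyl gives a 1.7-fold lower number from compound 1 to compound 3 (0.23 log units; within the scatter). From the compounds shown here alone, whether a Z double bond would give a similar difference alongside hexyl stays open. So does how an amine or a carboxylic acid in place of phenyl would read here.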